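This account rests on a few compounds, and the source may have more. Where it says the series, first, only, none or still open, it means among the compounds named here.

Measured in an ADME assay on a cell-free system (plasma, Rattus norvegicus) for protein binding, read by LC-MS, using equilibrium dialysis, with a stated time of 4 h, tested at 2.5 mM; a lower number here means a smaller unbound share, a higher number a larger unbound share of the compound:
- compound 1 `Cn1c(-c2cccnc2)nc2ccc(F)cc21`: 0.25
- compound 2 `Fc1cc2nc(-c3cccnc3)n(C3CC3)c2cc1F`: 0.15

For the measured compounds named here, these are the only two measured compounds. Compound 2, at 0.15, stands within the usual scatter of compound 1, at 0.25, so the two numbers cannot be told apart. Compound 3 `Fc1ccc2nc(-c3cccnc3)n(C3CC3)c2c1` has not yet been measured. It departs from compound 2 by hydrogen in place of fluoro on an aromatic carbon. Going by the values given here, no measured pair isolates this change, so the data offer no direct guide to its size. Among the compounds with values here, the only guide is the closeness of the two measured values. The expected move in this assay, a 1.3-fold higher number from compound 2 to compound 3 (0.12 log units; within the scatter), is therefore small, towards a slightly larger unbound share, and not beyond the scatter. For compound 3 the estimated value is 0.2, with an expected range from 0.11 to 0.36.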

Compound 3, unbound fraction: 0.15
Compound 3: the middle estimate sits 1.3-fold (0.12 log units) above what was measured; the measured number falls inside the stated range.
By their numbers in this assay, from the lowest: compounds 2, 3 and 1 (each within the scatter of the next).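

In this assay, hydrogen in place of fluoro on an aromatic carbon, ortho to a fluoro group, gives no change at the digits printed from compound 2 to compound 3 (within the scatter), so this position on the six-membered aromatic ring of carbon only now has a step of its own, and that step cannot be told from repeat measurement. Cyclopropyl in place of methyl on an aromatic nitrogen, which no earlier pair isolated, gives a 1.7-fold lower number from compound 1 to compound 3 (0.22 log units; within the scatter), so this change also stays unresolved. No measurement offered here accounts for either step.

The compounds shown leave open whether an amine or a methoxy group on this aromatic carbon, or a longer chain on the aromatic nitrogen, would shift the unbound fraction beyond the scatter. They also leave open what a carboxylic acid on the shared core would do to this read-out.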